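Swapping the trifluoromethylphenyl arm for a hydroxymethylphenyl

The source may report more compounds than this note shows. Statements on the series, on what has been measured and on what is new or still open speak of the compounds shown alone.

This account follows a series sharing a nitro-bearing dimethoxyphenyl core joined through a hydroxyethyl link to a biphenyl. Compound 1 `COc1cc(CC(O)c2ccc(-c3ccc(C(F)(F)F)cc3)cc2)c([N+](=O)[O-])cc1OC` carries a trifluoromethyl on the distal ring; in an ADME assay on HeLa Rh cells (Homo sapiens) for cytotoxicity, read by microscopy (a lower number here means that less compound is tolerated, a higher number that more compound is tolerated), compound 1 gives 4100 nM. Compound 3 `COc1cc(CC(O)c2ccc(-c3ccc(Br)cc3)cc2)c([N+](=O)[O-])cc1OC` carries bromo there instead, and in this assay compound 3 gives 4300 nM; the step of a 1.0-fold higher number from compound 1 to compound 3 (0.02 log units; within the scatter) stays within the scatter. Compound 2 `COc1ccc(-c2ccc(C(O)Cc3cc(OC)c(OC)cc3[N+](=O)[O-])cc2)cc1` carries methoxy there. For compound 2 this assay returns only a limit, > 244000 nM, meaning no number was reached (the limit of > 244000 nM in this assay, at which 1 of the 3 values shown sits). Among the two real numbers, compound 1 is the lowest, with compound 3 alongside it within the scatter.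

Compound 4 `COc1cc(CC(O)c2ccc(-c3cccc(CO)c3)cc2)c([N+](=O)[O-])cc1OC` is not yet measured. It differs from compound 1 thus: 3-(hydroxymethyl)phenyl in place of 4-(trifluoromethyl)phenyl on an aromatic carbon. The bromo step a 1.0-fold higher number from compound 1 to compound 3 (0.02 log units; within the scatter) shows that a replacement can leave the number unchanged, whereas the methoxy step an at least 59-fold higher number from compound 1 to compound 2 (1.77 log units; beyond the scatter) shows a large rise. The hydroxymethyl change introduces a donor and an acceptor, as the methoxy change introduced an acceptor, so a rise of uncertain size is anticipated. For compound 4 the expected step is a 9.8-fold higher number from compound 1 to compound 4 (0.99 log units; beyond the scatter). Compound 4 is therefore expected to give about 40000 nM, within a range from 8000 nM to 200000 nM, in this assay.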

Compound 4, half-maximal cytotoxic concentration: 6000 nM
For compound 4 the middle estimate is 6.7-fold (0.82 log units) above the measured one; the whole stated range lies above it.
By their numbers in this assay, from the lowest: compounds 1, 3 and 4 (each within the scatter of the next). At a limit, above all of these: compound 2.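

At this position the distal arm can take on a hydrogen-bond donor and a hydrogen-bond acceptor without a readable shift in this assay: the exchange for 3-(hydroxymethyl)phenyl gives a 1.5-fold higher number from compound 1 to compound 4 (0.17 log units; within the scatter), and the exchange starting from the bromo arm gives a 1.4-fold higher number from compound 3 to compound 4 (0.14 log units; within the scatter). The large rise seen with the methoxy arm is thus not shared by every oxygen-bearing arm in this set, and the gap to that arm appears as an at least 40-fold lower number from compound 2 to compound 4 (1.60 log units; beyond the scatter). That last step has only one firm end, since compound 2 is held at a limit of the assay and not at a number: the limit of > 244000 nM in this assay, at which 1 of the 4 values shown sits.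

In compound 4 the group and its place on the ring change together, so these compounds cannot show which of the two matters, or why compound 2 alone stands apart from compounds 1, 3 and 4. As far as these compounds go, it also remains open whether an amine, a carboxylic acid or a longer chain on this arm would stay with compounds 1, 3 and 4 or follow compound 2.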